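The source may report more compounds than this note shows. Statements on the series, on what has been measured and on what is new or still open speak of the compounds shown alone.

Compound 2 `O=C(Nc1cccc(-c2nc(-c3ccc(NC(=O)c4cccnc4)cc3Cl)no2)c1)Nc1cccc(C(F)(F)F)c1` is the point of departure. In a functional assay on MDA-MB-231 cells (Homo sapiens) for antiproliferative activity, read by MTT assay, with a stated time of 72 h (a lower number here means a stronger inhibitor, a higher number a weaker inhibitor), compound 2 gives 1900 nM. Compound 3 `O=C(Nc1cccc(-c2nc(-c3ccc(NC(=O)c4cccnc4)cc3Cl)no2)c1)Nc1cc(C(F)(F)F)cc(C(F)(F)F)c1` gives 1900 nM in this assay, and the step there is no change at the digits printed from compound 2 to compound 3 (within the scatter). Compound 1 `NC(=O)Nc1ccc(S(=O)(=O)Nc2cccc(-c3nc(-c4ccc(NC(=O)c5cccnc5)cc4Cl)no3)c2)cc1`, which carries a different linker, gives 2800 nM in this assay. Of the three numbers, compound 2 and compound 3 share the lowest, and compound 1 stands within the scatter of both, so no ordering among them can be claimed.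

The change from compound 2 to compound 4 `CC(=O)Nc1ccc(NC(=O)Nc2cccc(-c3nc(-c4ccc(NC(=O)c5cccnc5)cc4Cl)no3)c2)cc1Br` is 4-acetamido-3-bromophenyl in place of 3-(trifluoromethyl)phenyl on an amide-type nitrogen. For the measured compounds named here, only one measured step touches this position, and only loosely: no change at the digits printed from compound 2 to compound 3 (within the scatter) shows that a change on the aromatic ring attached to the amide-type nitrogen left the number where it was. Going by the values given here, no measured pair shows what a 4-acetamido-3-bromophenyl group does at that place. The expected step is therefore a 1.2-fold higher number from compound 2 to compound 4 (0.06 log units; within the scatter), none beyond the scatter. Compound 4 is expected to give 2200 nM in this assay, with a range from 900 nM to 5500 nM.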

Compound 4, half-maximal inhibitory concentration: 1000 nM
Beside the measured number, compound 4's estimate is 2.2-fold (0.34 log units) above it, within the range that was stated.
By their numbers in this assay, from the lowest: compounds 4, 2, 3 and 1 (each within the scatter of the next, the first and the last beyond it).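

In this assay, for the compounds shown here, the step is a 1.9-fold lower number from compound 2 to compound 4 (0.28 log units; within the scatter), so this position on the amide-type nitrogen accepts a far larger change than the earlier compounds showed, with no shift beyond the scatter. The earlier pair only added a trifluoromethyl group to the ring, whereas here the 3-(trifluoromethyl)phenyl group gives way entirely to 4-acetamido-3-bromophenyl, which loses all fluorine and brings in a hydrogen-bond donor and acceptor. Nothing available explains this result.

The compounds shown do not tell whether the acetamido group or the bromine matters more on its own at this position. As far as these compounds go, it also remains open whether a carboxylic acid or an amine on this ring, or a cyclohexyl ring in place of the phenyl, would move the number beyond the scatter.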